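The compounds below may be only part of what the source reports. "The series", "measured", "known", "first", "only" and "open" are said of these compounds alone.

In a physicochemical assay for lipophilicity, using the shake flask method (a lower number here means a more polar compound, a higher number a more lipophilic compound), compound 1 `C[C@H](Oc1ccc2ncc(CCC(=O)O)c(C3CC3)c2c1)c1c(Cl)ccc(F)c1Cl` gives 4.1 and compound 2 `C[C@H](Oc1ccc2ncc(-c3ccn(CCC(=O)O)n3)c(C3CC3)c2c1)c1c(Cl)cccc1Cl` gives 2.7. Compound 3 `C[C@H](Oc1ccc2ncc(/C=C/S(=O)(=O)O)c(C3CC3)c2c1)c1c(Cl)ccc(F)c1Cl` gives 2.5, which lies within the scatter of compound 2. Compound 4 `C[C@H](Oc1ccc2ncc(/C=C/C(=O)NC(CC(=O)O)CC(=O)O)c(C3CC3)c2c1)c1c(Cl)ccc(F)c1Cl` differs from compound 3 by (2-carboxy-1-(carboxymethyl)ethyl)carbamoyl in place of sulfo on a double-bonded chain carbon bound to a double-bonded chain carbon. The closest measured step is a number 1.60 log units lower from compound 1 to compound 3 (beyond the scatter), a large one that brought in the sulfo-bearing chain. Going by the values given here, no measured step removes sulfo or brings in the entering group, so that step bears on the change only loosely. A modest step to a lower number is therefore expected in this assay, much smaller than that large one. The estimated step is a number 0.40 log units lower from compound 3 to compound 4 (beyond the scatter). For compound 4 the expected value is 2.1, with an estimated range from 1.4 to 2.9.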

Compound 4, distribution coefficient: 0.4
Beside the measured number, compound 4's estimate is 1.70 log units above it, outside the stated range (below it).
By their numbers in this assay, from the lowest: compound 4; then compounds 3 and 2 (each within the scatter of the next); then compound 1.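

In this assay, (2-carboxy-1-(carboxymethyl)ethyl)carbamoyl in place of sulfo on a double-bonded chain carbon bound to a double-bonded chain carbon gives a number 2.10 log units lower from compound 3 to compound 4 (beyond the scatter) as a large step. The earlier compounds shown here showed a number 1.60 log units lower from compound 1 to compound 3 (beyond the scatter) on reaching sulfo at this chain, and the new step shows that replacing sulfo itself can also move the number a long way. Nothing available explains the size of this step. On these data alone, it remains open whether the step follows the amide link or the two carboxylic acid arms. A carbamoyl bearing a single carboxymethyl chain, or an amine in place of one acid, would separate these.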